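The source may report more compounds than this note shows. Statements on the series, on what has been measured and on what is new or still open speak of the compounds shown alone.

Working notes on the glycine transporter series.

Two compounds carry numbers. Compound 1 `O=C(CNC(=O)c1ccccc1)NC(c1ccccc1)c1ccc(Cl)cc1` in an assay for inhibition of sodium- and chloride-dependent glycine transporter 1 (Homo sapiens) (on this read-out lower numbers stand for an effect already at smaller amounts and higher numbers for an effect only at larger amounts of compound), gives 390 nM. Compound 2 `Cc1cccc(C(NC(=O)CNC(=O)c2ccc(F)cc2)c2ccccc2)c1` in this assay gives 56 nM, the lowest of the two numbers; the gap to compound 1 is beyond the scatter, so compound 2 stands as the stronger of the pair.

Compound 3 `CCC(NC(=O)CNC(=O)c1ccc(F)cc1)c1ccccc1` is not yet measured. It differs from compound 2 in one place: ethyl in place of 3-methylphenyl on a saturated chain carbon bound to an amide-type nitrogen and an aromatic carbon. For the measured compounds named here, no pair of measured compounds shares this kind of change, so there is no measured step to lean on; what is known is that both measured compounds carry two aromatic rings on that chain carbon, and compound 3 keeps only one.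

The expectation is a step toward a higher number, larger than the scatter: a 36-fold higher number from compound 2 to compound 3 (1.55 log units; beyond the scatter) is expected. Going by the values given here, for compound 3 in this assay the estimate is 2000 nM, with a range from 300 nM to 12000 nM; the range is wide because no step tests this change.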

Compound 3, half-maximal effective concentration: 4100 nM
Compound 3: middle estimate off by 2.1-fold (0.31 log units), on the low side; low and high end bracket the measured number.
By their numbers in this assay, from the lowest: compound 2; then compound 1; then compound 3.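

For the compounds shown here, the step to ethyl gives the first measured reading on the saturated chain carbon bound to an amide-type nitrogen and an aromatic carbon: it shows a 73-fold higher number from compound 2 to compound 3 (1.86 log units; beyond the scatter) in this assay and marks this place as one where the choice of group carries a large change in the number. The 3-methylphenyl group, with 7 heavy atoms and one six-membered aromatic ring of carbon only, gives way to ethyl, with 2 heavy atoms and no ring, and in this single pair the lower number goes with the ring-bearing group. No measurement at hand accounts for the size of this step.

This one pair cannot tell whether the number follows the aromatic ring itself or simply the count of heavy atoms at this place. A cyclohexyl group would separate those two readings, while a benzyl group, a longer chain such as n-hexyl or an amine such as dimethylaminomethyl would show how far other groups at this place hold the number near that of compound 2.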